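Triazole carboxamide series: aryl swap on the triazole nitrogen

The source may report more compounds than this note shows. Statements on the series, on what has been measured and on what is new or still open speak of the compounds shown alone.

Two compounds of the series have numbers in a functional assay on NCI-H460 cells (Homo sapiens) for cytotoxicity, read by MTT assay, with a stated time of 72 h; on this read-out higher numbers stand for weaker inhibition and lower numbers for stronger inhibition. Compound 1 `COc1cc2c(Oc3ccc(NC(=O)c4nnn(-c5ccc(F)c(F)c5)c4C(F)(F)F)cc3F)ccnc2cc1OCCCN1CCCCC1` gives 210 nM in this assay. Compound 2 `COc1cc2c(Oc3ccc(NC(=O)c4nnn(-c5ccccc5C(F)(F)F)c4C(F)(F)F)cc3F)ccnc2cc1OCCCN1CCC(C)CC1` gives 250 nM in this assay, the higher of the two numbers, yet the gap to compound 1 lies within the scatter, so the two read as equivalent on this read-out.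

Compound 3 `COc1cc2c(Oc3ccc(NC(=O)c4nnn(-c5ccc(F)c(F)c5)c4C(F)(F)F)cc3F)ccnc2cc1OCCCN1CCC(C)CC1` is the next member to be measured. It keeps the whole of compound 2 apart from one change: 3,4-difluorophenyl in place of 2-(trifluoromethyl)phenyl on an aromatic nitrogen. The 3,4-difluorophenyl that enters is the same aryl group carried by compound 1, so compound 3 pairs that group with the remainder of compound 2.

Going by the values given here, no measured pair isolates this aryl exchange, so its effect cannot be read directly. What is known is that compound 1, bearing the entering group, and compound 2, bearing the leaving group, sit within the scatter of each other in this assay. On that basis the step from compound 2 to compound 3 is expected to be a 1.1-fold lower number from compound 2 to compound 3 (0.06 log units; within the scatter), that is, no shift beyond the scatter in either direction. Compound 3 is therefore estimated at 220 nM in this assay, with a range from 100 nM to 500 nM.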

Compound 3, half-maximal inhibitory concentration: 230 nM
Beside the measured number, compound 3's estimate is 1.0-fold (0.02 log units) below it; the range from low to high includes it.
By their numbers in this assay, from the lowest: compounds 1, 3 and 2 (each within the scatter of the next).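

Notes on the aromatic nitrogen position: in this assay, the exchange of 2-(trifluoromethyl)phenyl for 3,4-difluorophenyl now stands alone in one pair (a 1.1-fold lower number from compound 2 to compound 3 (0.04 log units; within the scatter)), so the effect of this aryl swap can be read directly rather than inferred, and it stays within the scatter even though the entering group has fewer heavy atoms than the group that leaves. The series also gains its first single-place step away from this position, methyl in place of hydrogen on a saturated ring carbon (a 1.1-fold higher number from compound 1 to compound 3 (0.04 log units; within the scatter)), and that change too stays within the scatter in this assay. Nothing available explains why either change leaves the number within the scatter.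

As far as these compounds go, both aryl groups compared here carry fluorine, so it remains open whether unsubstituted phenyl, a pyridyl ring or an aryl group bearing a carboxylic acid on the aromatic nitrogen would keep the number within the scatter. Also open, from the compounds shown here alone, are a longer chain such as ethyl or a hydroxyl group in place of the methyl on the saturated ring carbon, and a nitrile in place of the trifluoromethyl group on the five-membered aromatic ring.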